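Methyl-for-hydrogen steps in a small binding series

This account rests on a few compounds, and the source may have more. Where it says the series, first, only, none or still open, it means among the compounds named here.

Measured compounds:
compound 1 `CCOC(=O)C1=C(CC)NC(=O)NC1c1ccco1`: 3%
compound 2 `CCCC1=C(C(=O)OCC)C(c2ccco2)NC(=O)N1`: 19%
compound 3 `CCOC(=O)C1=C(C)N(C)C(=O)NC1c1cccs1`: 6%

In an assay on HeLa cells for displacement of a labelled ligand from adenosine receptor A3 (Homo sapiens), with a stated time of 180 min, tested at 10 uM (on this read-out lower numbers stand for less inhibition and higher numbers for more inhibition at the one concentration tested (going by the name of the read-out)), compound 1 gives 3%, compound 2 gives 19% and compound 3 gives 6%. Compound 2 differs from compound 1 by methyl in place of hydrogen on a saturated chain carbon, two bonds along the chain from a double-bonded ring carbon; this change made a step of a number 16 percentage points higher from compound 1 to compound 2 (beyond the scatter). Compound 3 and compound 1 lie within the scatter of each other, while compound 2 stands above compound 3 beyond the scatter. Compound 3 and compound 1 share no single counted difference; the difference between the two cores is not broken down here.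

Compound 4 `CC1=C(C(=O)OC(C)C)C(c2cccs2)NC(=O)N1C` is not yet measured. It differs from compound 3 by methyl in place of hydrogen on a saturated chain carbon bound to an oxygen next to a carbonyl group and a saturated chain carbon. This is the same kind of change as from compound 1 to compound 2, but not the same: there the methyl entered on a saturated chain carbon, two bonds along the chain from a double-bonded ring carbon; here it enters on a saturated chain carbon bound to an oxygen next to a carbonyl group and a saturated chain carbon. Among the measured compounds shown here, only one measured pair shows this kind of change, and its place differs, so it is a loose guide. For the measured compounds named here, for compound 4 in this assay a step of a number 6 percentage points higher from compound 3 to compound 4 (within the scatter) is expected, smaller than the earlier one, because the only comparable step from compound 1 to compound 2 is a number 16 percentage points higher from compound 1 to compound 2 (beyond the scatter) and was made at a different place. Compound 4 is estimated at 12%, with a range from 2% to 25%.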

Compound 4, a percentage reported as inhibition, at one concentration (the size of the read-out at that concentration, not a potency): 18%
Compound 4: the middle estimate sits 6 percentage points below what was measured; measured number inside the range.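

In this assay, methyl in place of hydrogen, which here turns ethoxycarbonyl into isopropoxycarbonyl, gives a number 12 percentage points higher from compound 3 to compound 4 (beyond the scatter). Set beside the earlier methyl step on the other core, the new step does not differ in size: the same change on two cores in this assay, a number 16 percentage points higher (beyond the scatter) from compound 1 to compound 2 and a number 12 percentage points higher (beyond the scatter) from compound 3 to compound 4, 4 percentage points apart, within the scatter of two such steps

This does not show that one change carries over from core to core, as the methyl sits at a different place in each pair: on a saturated chain carbon, two bonds along the chain from a double-bonded ring carbon, in one, and on a saturated chain carbon bound to an oxygen next to a carbonyl group and a saturated chain carbon, in the other; the two pairs show steps of similar size at two places on two cores, and each step is a difference in inhibition at one concentration, not in potency.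

Still open, as far as these compounds go, is whether the methyl at either place would give a step of like size on the other core. Also open, from the compounds shown here alone, is what a longer chain on the ester or a carboxylic acid in place of the ester would do to the inhibition read-out on either core.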